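Working notes: aryl swap on the aromatic nitrogen

The source may hold more compounds than are shown below. What is called first, only, known or untested is meant among the compounds shown, and "the series" means these compounds.

Measured so far:
compound 1 `CC(C)(C)c1ccc(-n2nc(-c3ccc(C(F)(F)F)cc3O)nc2-c2ccccc2O)cc1`: 81.1%
compound 2 `Oc1cc(C(F)(F)F)ccc1-c1nc(-c2ccccc2O)n(-c2ccccc2F)n1`: 100%

In a functional assay on PC-12 cells (Rattus norvegicus) for cytotoxicity, read by MTT assay, with stated times of 2 h and 24 h, tested at 10 uM (on this read-out higher numbers stand for a stronger effect at the one concentration tested and lower numbers for a weaker effect), compound 1 gives 81.1% and compound 2 gives 100%. Compound 2 stands highest of the two numbers shown; its only neighbour is compound 1, and the step of a number 18.9 percentage points higher from compound 1 to compound 2 (beyond the scatter) lies beyond the scatter. For the measured compounds named here, no other measured compound touches the aryl group on the aromatic nitrogen.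

Compound 3 `Oc1cc(C(F)(F)F)ccc1-c1nc(-c2ccccc2O)n(-c2cccc(Cl)c2)n1` is not yet measured. It differs from compound 2 by 3-chlorophenyl in place of 2-fluorophenyl on an aromatic nitrogen. Going by the values given here, the one step that bears on this position, a number 18.9 percentage points higher from compound 1 to compound 2 (beyond the scatter), shows that exchanging the aryl group on the aromatic nitrogen can move the read-out beyond the scatter, but that step compared 4-(tert-butyl)phenyl with 2-fluorophenyl, not 2-fluorophenyl with 3-chlorophenyl, so neither its size nor its direction carries over directly. Both groups that change here carry a single halogen on a six-membered aromatic ring of carbon only, and the present read-out of compound 2 already sits at the top of the two numbers. Compound 3 is therefore expected to stay close to compound 2, with a step of a number 10 percentage points lower from compound 2 to compound 3 (within the scatter) expected to be small or none beyond the scatter. The estimate for compound 3 is 90%, within 70% to 100%.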

Compound 3, a percentage reported as activity, at one concentration (the size of the read-out at that concentration, not a potency): 100%
For compound 3 the middle estimate is 10 percentage points below the measured one; measured number inside the range.
By their numbers in this assay, from the lowest: compound 1; then compounds 2 and 3 (each within the scatter of the next).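

In this assay, the exchange of 2-fluorophenyl for 3-chlorophenyl on the aromatic nitrogen gives no change at the digits printed from compound 2 to compound 3 (within the scatter), so these two halogen-bearing phenyl groups cannot be told apart at this position on this read-out. The comparison with 4-(tert-butyl)phenyl now rests on two steps instead of one: a number 18.9 percentage points higher from compound 1 to compound 3 (beyond the scatter) sits alongside a number 18.9 percentage points higher from compound 1 to compound 2 (beyond the scatter), and among the three compounds shown, both halogen-bearing phenyl groups separate from 4-(tert-butyl)phenyl beyond the scatter, with no compound going against this. No supporting data are available to explain the read-outs of this series.

From the compounds shown here alone, it remains open whether this position tolerates a group of another kind, such as a phenyl ring carrying a carboxylic acid or an amine, or a saturated alkyl chain in place of the aryl ring. Going by these compounds, it is also open whether the read-outs of compound 2 and compound 3 would still match at other concentrations, since a single concentration says nothing about potency.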